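Swapping iodo for thiophen-2-yl on a nucleoside core

This account rests on a few compounds, and the source may have more. Where it says the series, first, only, none or still open, it means among the compounds named here.

Measured compounds:
compound 1, `Cc1ncnc2c1c(I)cn2[C@@H]1O[C@H](CO)[C@@H](O)[C@H]1O`, 5480 nM
compound 2, `COc1nc(N)nc2c1c(-c1ccsc1)cn2[C@@H]1O[C@H](CO)[C@@H](O)[C@H]1O`, > 20000 nM

Of the compounds shown here, two have been measured in a functional assay on CCRF-CEM cells (Homo sapiens), read by MTT assay, with a stated time of 72 h; a higher number here means a weaker inhibitor, a lower number a stronger inhibitor. Compound 1, `Cc1ncnc2c1c(I)cn2[C@@H]1O[C@H](CO)[C@@H](O)[C@H]1O`, gives 5480 nM in this assay. For compound 2, `COc1nc(N)nc2c1c(-c1ccsc1)cn2[C@@H]1O[C@H](CO)[C@@H](O)[C@H]1O`, the assay reports only a limit, > 20000 nM. For the measured compounds named here, compound 1 thus stands as the only numerical value shown. One of the two results is the limit of > 20000 nM in this assay, at which 1 of the 2 values shown sits.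

Compound 3, `Cc1ncnc2c1c(-c1cccs1)cn2[C@@H]1O[C@H](CO)[C@@H](O)[C@H]1O`, has not yet been measured. It differs from compound 1 in one place: thiophen-2-yl in place of iodo on an aromatic carbon. Going by the values given here, compound 2 shares no single-point difference with compound 1, so no measured step covers this change, and the expectation rests on the structural change alone. The author expects the step from compound 1 to compound 3 to weaken inhibition moderately, a 2.0-fold higher number from compound 1 to compound 3 (0.30 log units; within the scatter), with a real chance that only a limit is reported. Compound 3 is estimated at 11000 nM, between 3000 nM and 30000 nM.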

Compound 3, half-maximal inhibitory concentration: > 20000 nM
Compound 3: only a limit was reported (the forecaster's own chance of this, stated with the estimate: 30%); middle value at least 1.8-fold (0.25 log units) away from the limit.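

Read at this aromatic carbon, the change from iodo to thiophen-2-yl gives an at least 3.6-fold higher number from compound 1 to compound 3 (0.56 log units; beyond the scatter), the first step available at this position. In this assay, compound 3 gives only a limit, > 20000 nM, so the step sets a minimum size for the loss and not its full extent. Compound 1 remains the only compound with a numerical value, and a second compound now ends at the same limit: the limit of > 20000 nM in this assay, at which 2 of the 3 values shown sit.

On these data alone, how far compound 3 actually lies from compound 1 stays open, as does whether the loss belongs to thiophen-2-yl alone or would also follow other aromatic rings here. As far as these compounds go, it is equally open how a bromo group, a methyl group or an amine on this aromatic carbon would compare with iodo.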